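This account rests on a few compounds, and the source may have more. Where it says the series, first, only, none or still open, it means among the compounds named here.

Measured so far in an assay on HEK293 cells for displacement of a labelled ligand from metabotropic glutamate receptor 5 (Rattus norvegicus); a higher number here means a weaker inhibitor, a lower number a stronger inhibitor:

Compound 1 `COc1cccc(C(=O)Nc2cc(-c3ccccc3)nn2-c2ccccc2)c1` gives 1290 nM in this assay.
Compound 2 `O=C(Nc1cc(-c2ccccc2)nn1-c1ccccc1Cl)c1ccccc1` gives 500 nM in this assay.
Compound 3 `COc1cccc(-n2nc(-c3ccccc3)cc2NC(=O)c2ccccc2)c1` gives 2100 nM in this assay.

For the measured compounds named here, of the three numbers, the one for compound 1 is the second highest. Its gap to compound 3 lies within the scatter, so the two cannot be told apart; compound 2 alone is clearly separated from compound 1, with a lower number beyond the scatter.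

Going by the values given here, only one step between measured compounds differs in a single place: a 4.2-fold higher number from compound 2 to compound 3 (0.62 log units; beyond the scatter). That change sits on the aromatic nitrogen of the shared core.

Compound 4 `O=C(Nc1cc(-c2ccccc2)nn1-c1ccccc1)C1=CCCCC1` is the unmeasured compound. It differs from compound 1 as follows: cyclohex-1-en-1-yl in place of 3-methoxyphenyl on a carbonyl carbon. Among the compounds with values here, the change sits on the carbonyl carbon, a different place from the one probed by the step from compound 2 to compound 3, so that step does not bear on it directly, and no measured pair shows what a non-aromatic ring on the carbonyl carbon does in this assay. Within the data shown here, with no precedent, a modest weakening is expected, roughly a 1.9-fold higher number from compound 1 to compound 4 (0.29 log units; within the scatter), with wide uncertainty. Compound 4 is therefore estimated at 2500 nM in this assay, with a range from 800 nM to 8000 nM.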

Compound 4, inhibition constant: 4470 nM
Beside the measured number, compound 4's estimate is 1.8-fold (0.25 log units) below it; measured number inside the range.
By their numbers in this assay, from the lowest: compound 2; then compounds 1 and 3 (each within the scatter of the next); then compound 4.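

In this assay the carbonyl carbon now has a reading of its own: cyclohex-1-en-1-yl in place of 3-methoxyphenyl gives a 3.5-fold higher number from compound 1 to compound 4 (0.54 log units; beyond the scatter) and so moves the number beyond the scatter. The aromatic nitrogen was the only place with such a step until now, so the shown compounds have two places where a change of group separates a pair, and at the carbonyl carbon the non-aromatic ring goes with the higher number. The step bundles several differences, since the ring stops being aromatic, a double bond outside an aromatic ring enters and the hydrogen-bond acceptor of the leaving group is gone, and no information at hand accounts for the size of this step.

Which of these differences carries the step remains open, as a single pair cannot divide it among them. Also open, as far as these compounds go, is where a fully saturated cyclohexyl ring, a pyridyl ring or an open pentyl chain on the carbonyl carbon would fall relative to compound 1 and compound 4 in this assay on this shared core.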